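Propoxy to ethoxy on the aromatic ring: compound 4

The source may report more compounds than this note shows. Statements on the series, on what has been measured and on what is new or still open speak of the compounds shown alone.

Of the compounds shown here, three have numbers so far; all share the same core and differ in the ether on the aromatic ring and in the carbamate esters. Compound 1 `COC(=O)N1[C@@H]2C=C[C@@](OC)(C(=O)c3c2cc(OC)c(OC)c3OCc2ccc(F)cc2)N1C(=O)OC` in an ADME assay on KB cells (Homo sapiens) for cytotoxicity (on this read-out higher numbers stand for an effect only at larger amounts of compound and lower numbers for an effect already at smaller amounts), gives 56.6 ug/mL. Compound 3 `CCOC(=O)N1[C@@H]2C=C[C@@](OC)(C(=O)c3c2cc(OC)c(OC)c3OCc2ccccc2F)N1C(=O)OCC` in this assay gives 99.7 ug/mL. Compound 2 `CCCOc1c(OC)c(OC)cc2c1C(=O)[C@]1(OC)C=C[C@H]2N(C(=O)OCC(C)C)N1C(=O)OCC(C)C` in this assay gives 299 ug/mL, the highest number of the three; the gaps to compound 3 and to compound 1 both lie beyond the scatter. Among the compounds with values here, no pair of measured compounds differs in a single place, so no isolated step is available as a reference.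

Compound 4 `CCOc1c(OC)c(OC)cc2c1C(=O)[C@]1(OC)C=C[C@H]2N(C(=O)OCC(C)C)N1C(=O)OCC(C)C` has not yet been measured in this assay. Its relation to compound 2 is a single change, (hydrogen in place of methyl on a saturated chain carbon, two bonds along the chain from an oxygen on an aromatic ring), which removes one carbon from the chain and alters nothing else. Within the data shown here, nothing among the measured compounds speaks to this change on its own. The expected step of a 1.2-fold lower number from compound 2 to compound 4 (0.08 log units; within the scatter) is small, within the scatter, with no clear direction. Compound 4 is therefore estimated to give 250 ug/mL in this assay, with a range from 120 ug/mL to 500 ug/mL.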

Compound 4, concentration for half-maximal effect: > 300 ug/mL
Compound 4 was reported as a limit; the forecaster's own chance of this, stated with the estimate: 10%; middle value at least 1.2-fold (0.07 log units) away from the limit.
By their numbers in this assay, from the lowest: compounds 1 and 3 (each within the scatter of the next); then compound 2. At a limit, above all of these: compound 4.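

Propoxy to ethoxy on the aromatic ring gives a number no lower from compound 2 to compound 4 (the limit leaves the size open) in this assay, and this is the only single-place step among the compounds shown. For compound 4, the reported > 300 ug/mL is a limit and not a number. Removing one carbon from this chain therefore does not lower the number, but the size of the step cannot be read, and it cannot be told whether the chain length matters at all here, because the value sits at a limit: the limit of > 300 ug/mL in this assay, at which 1 of the 4 values shown sits.

The compounds shown leave open what a longer chain at this place, such as butoxy, or a chain ending in an amine or a carboxylic acid would do with the rest of the structure of compound 2 held unchanged, and whether any such group would bring the number down to a readable value. Within the data shown here, they also leave open how much the carbamate esters and the ether on the aromatic ring each contribute on their own, as no single-place step for the esters, or for the fluorobenzyl ethers, stands among them.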